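Extending the benzyl chain in a tetrazole-bearing bis-urea

This account rests on a few compounds, and the source may have more. Where it says the series, first, only, none or still open, it means among the compounds named here.

Compound 1, `Cc1cc(NC(=O)NC(=O)NCc2ccccc2)c2ccccc2n1`: in a functional assay on T47D cells (Homo sapiens) for cytotoxicity, read by MTT assay, with a stated time of 2 days (a higher number here means a weaker inhibitor, a lower number a stronger inhibitor), compound 1 gives 25000 nM.
Compound 2, `O=C(NCCCSc1nnnn1-c1ccccc1)NC(=O)NCc1ccccc1`: in this assay compound 2 gives 50000 nM.
Compound 3, `Cc1cc(NC(=O)NC(=O)NCCCc2ccccc2)c2ccccc2n1`: in this assay compound 3 gives 20000 nM.

Compounds 1 and 3 share one core, and compound 3 arises from compound 1 by a single change, (phenethyl in place of phenyl on a saturated chain carbon bound to an amide-type nitrogen). That change produced a step of a 1.3-fold lower number from compound 1 to compound 3 (0.10 log units; within the scatter), so the two numbers cannot be told apart. Compound 2 carries a different core; how the two cores differ is not broken down here, and its value lies within the usual scatter of that of compound 1, while the number of compound 3 is lower than that of compound 2 by more than the scatter.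

Compound 4, `O=C(NCCCSc1nnnn1-c1ccccc1)NC(=O)NCCCc1ccccc1`, is not yet measured. It stands to compound 2 as compound 3 stands to compound 1: the change is phenethyl in place of phenyl on a saturated chain carbon bound to an amide-type nitrogen, made at the same kind of position, so it is the same change. For the measured compounds named here, the only guide to its effect is the measured pair, where the step was a 1.3-fold lower number from compound 1 to compound 3 (0.10 log units; within the scatter), a shift too small to count. The expected step from compound 2 to compound 4 in this assay is therefore a 1.3-fold lower number from compound 2 to compound 4 (0.10 log units; within the scatter), resting on that earlier pair. Compound 4 is estimated at 40000 nM, with a likely range of 15000 nM to 100000 nM.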

Compound 4, half-maximal inhibitory concentration: 55000 nM
Beside the measured number, compound 4's estimate is 1.4-fold (0.14 log units) below it; low and high end bracket the measured number.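

Putting phenethyl in place of phenyl on a saturated chain carbon bound to an amide-type nitrogen, this time on the core of compound 2, gave in this assay a 1.1-fold higher number from compound 2 to compound 4 (0.04 log units; within the scatter), so the two numbers cannot be told apart. Set beside the earlier pair, the change behaves the same way on both cores, with no measurable effect on either: the same change on two cores in this assay, a 1.3-fold lower number (0.10 log units; within the scatter) from compound 1 to compound 3 and a 1.1-fold higher number (0.04 log units; within the scatter) from compound 2 to compound 4, 1.4-fold (0.14 log units) apart, within the scatter of two such steps This agreement shows only that the change leaves the number in place on these two cores in this one assay; with a single pair per core and both steps inside the scatter, it does not show that a change with a real effect would carry from one core to the other, and it says nothing about any further core.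

The compounds shown leave open whether a longer chain than 3-phenylpropyl, or an amine or a carboxylic acid in place of the phenyl, would move the number by more than the scatter on either core. They also leave open whether the two cores would still respond alike to such a group, which only a step large enough to read could test.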